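Extending the Pyridyl Group on the Chain Carbon

This account rests on a few compounds, and the source may have more. Where it says the series, first, only, none or still open, it means among the compounds named here.

Compound 2 `CCOC(=O)C1=C(Nc2ccccc2)S/C(=C\c2cccnc2)C1=O` carries a pyridin-3-yl group on a double-bonded chain carbon bound to a double-bonded ring carbon. In a functional assay on MCF7 cells (Homo sapiens) for inhibition, read by MTT assay, with a stated time of 72 h, tested at 10 uM (a higher number here means more inhibition at the concentration tested (going by the name of the read-out), a lower number less inhibition), compound 2 gives only a limit, < 10%. Compound 1 `CCOC(=O)C1=C(Nc2ccccc2)S/C(=C\c2cccc(C(=O)O)c2)C1=O` likewise gives a limit in this assay, < 10%. The step that the two limits leave unreadable from compound 1 to compound 2 is unreadable, and the limit of < 10% in this assay, at which 2 of the 2 values shown sit, is all the two compounds show. Compound 3 `CCOC(=O)C1=C(Nc2ccccc2)S/C(=C\c2cc3cccnc3[nH]2)C1=O` differs from compound 2 by a group of 9 heavy atoms (7 carbon, 2 nitrogen; one five-membered aromatic ring with 1 hetero atom, one six-membered aromatic ring with 1 hetero atom) in place of a group of 6 heavy atoms (5 carbon, 1 nitrogen; one six-membered aromatic ring with 1 hetero atom), on a double-bonded chain carbon bound to a double-bonded ring carbon. Going by the values given here, no measured step reads on this change, so compound 3 is expected to stay near the limit, with an estimated step that the limit leaves unreadable from compound 2 to compound 3. Compound 3 is estimated at 8%, from 0% to 25%.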

Compound 3, a percentage reported as inhibition, at one concentration (the size of the read-out at that concentration, not a potency): 18.2%
Compound 3: middle estimate off by 10.2 percentage points, on the low side; the range from low to high includes it.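

Compound 3 is the only compound shown that gives a number rather than a limit in this assay, so a substituent at this place on the double-bonded chain carbon can yield a readable result: the limit of < 10% in this assay, at which 2 of the 3 values shown sit. The change from pyridin-3-yl reads as a number at least 8.2 percentage points higher from compound 2 to compound 3 (that floor lies within the scatter), and the change from 3-carboxyphenyl reads as a number at least 8.2 percentage points higher from compound 1 to compound 3 (that floor lies within the scatter). Neither floor shows a gain beyond the scatter.

The compounds shown leave open whether the five-membered ring or its hydrogen-bond donor goes with this reading. They also leave open what an amine or a methoxy group on the pyridin-3-yl ring would give.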